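The source may hold more compounds than are shown below. What is called first, only, known or untested is meant among the compounds shown, and "the series" means these compounds.

Compound 1 `CCC(CC)c1ccc2c(NCCCNCc3cc(F)ccc3OC)ccnc2c1` gives 7860 nM in an ADME assay on HepG2 cells (Homo sapiens) for cytotoxicity, read by luminescence, CellTiter-Glo and ATP content, with a stated time of 72 h (a lower number here means that less compound is needed, a higher number that more compound is needed for the effect), the highest of the three numbers recorded so far. Within the data shown here, compound 2 `CCC(CC)c1ccc2c(NCCCNCc3ccco3)ccnc2c1` gives 6760 nM, and the step of a 1.2-fold lower number from compound 1 to compound 2 (0.07 log units; within the scatter) is the only single-point change measured. Among the measured compounds shown here, compound 3 `COc1cccc(CNCCCNc2ccnc3cc(Cc4cccc(C(F)(F)F)c4)ccc23)c1O` differs from compound 1 in several places, and no step is computed for that pair. Compound 3 gives 1720 nM, a lower number beyond the scatter. Compound 4 `COc1ccc(F)cc1CNCCCNc1ccnc2cc(Oc3ccc(Cl)cc3)ccc12` is not yet measured; relative to compound 1 the change is 4-chlorophenoxy in place of pentan-3-yl on an aromatic carbon. For the measured compounds named here, no measured step touches this position, so the measured step bears on it only weakly. Given the lower number of compound 3, a lower number for compound 4 is expected, a 2.6-fold lower number from compound 1 to compound 4 (0.42 log units; beyond the scatter). The estimate for compound 4 is 3000 nM, expected between 1200 nM and 7500 nM.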

Compound 4, half-maximal effective concentration: 4500 nM
Compound 4: middle estimate off by 1.5-fold (0.18 log units), on the low side, within the range that was stated.
By their numbers in this assay, from the lowest: compound 3; then compounds 4, 2 and 1 (each within the scatter of the next).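

In this assay, among these compounds, the first measured change at this position, 4-chlorophenoxy in place of pentan-3-yl on the aromatic carbon of the shared core, gives a 1.7-fold lower number from compound 1 to compound 4 (0.24 log units; within the scatter) and so no shift beyond the scatter. At this position, a group with an aromatic ring and an ether oxygen therefore reads the same as the open-chain group it replaces. Nothing on hand explains this result.

Still open, from the compounds shown here alone, is how an amine or a carboxylic acid would read on this carbon. Also open, going by these compounds, is whether 4-chlorophenoxy reads the same when paired with the furan-2-yl side chain of compound 2.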